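This account rests on a few compounds, and the source may have more. Where it says the series, first, only, none or still open, it means among the compounds named here.

Compound 1 `N#Cc1ccc(NC(=O)c2cc(Cl)ccc2O)c(Cl)c1`: 860 nM
Compound 2 `N#Cc1ccc(NC(=O)c2cc(Cl)ccc2O)cc1`: 1860 nM
Compound 3 `O=C(Nc1ccc(C(F)(F)F)cc1)c1cc(Br)c(F)cc1O`: 820 nM

In a functional assay on KG-1 cells (Homo sapiens) for cytotoxicity, read by luminescence and CellTiter-Glo, with a stated time of 3 days (a higher number here means a weaker inhibitor, a lower number a stronger inhibitor), compound 1 gives 860 nM, second highest of the three numbers but within the usual scatter of compound 3 at 820 nM. Only compound 2 stands clearly apart from it, with a 2.2-fold higher number from compound 1 to compound 2 (0.34 log units; beyond the scatter).

Compound 4 `O=C(Nc1ccc(OC(F)(F)F)cc1Cl)c1cc(Cl)ccc1O` has not yet been measured. Its difference from compound 1 is trifluoromethoxy in place of cyano on an aromatic carbon, meta to a chloro group and para to a large group.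

Among the measured compounds shown here, no measured step makes this exchange. For the measured compounds named here, the single step available, the modest loss of chloro between compound 1 and compound 2, concerns a different place, and compound 4 keeps that chloro. The nearest hint is compound 3, which carries trifluoromethyl and no nitrile and still gives 820 nM, though it differs from compound 1 in several places and so offers only loose support. On this thin evidence, no step beyond the scatter is expected in this assay, and neither direction can be favoured with confidence. The estimate amounts to a 1.2-fold lower number from compound 1 to compound 4 (0.09 log units; within the scatter). For compound 4 the expected value is 700 nM, with an estimated range from 250 nM to 2000 nM.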

Compound 4, half-maximal inhibitory concentration: 620 nM
Beside the measured number, compound 4's estimate is 1.1-fold (0.05 log units) above it; low and high end bracket the measured number.
By their numbers in this assay, from the lowest: compounds 4, 3 and 1 (each within the scatter of the next); then compound 2.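

Among the compounds shown here, at the position para to a large group and meta to a chloro group, the earlier compounds offered no direct comparison, and this exchange provides the first: in this assay, replacing cyano with trifluoromethoxy gives a 1.4-fold lower number from compound 1 to compound 4 (0.14 log units; within the scatter). The nitrile is therefore not needed to hold the number at this level in this pair, and a group with more heavy atoms, containing oxygen and fluorine and lacking the triple bond, is accepted here without a change beyond the scatter. For the compounds shown here, this contrasts with the only earlier single-place step, at the chloro group, which gives a 2.2-fold higher number from compound 1 to compound 2 (0.34 log units; beyond the scatter) and lies beyond the scatter, although no information is available on why the two places differ in this way.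

The compounds shown leave open how far this tolerance extends at the same position, for example to an amine, a carboxylic acid or a longer chain, since only cyano and trifluoromethoxy can be compared there directly. Going by these compounds alone, they also leave open whether trifluoromethoxy would be tolerated equally well with hydrogen in place of the chloro group, as the single comparison here has that chloro group present on both sides.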